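This account rests on a few compounds, and the source may have more. Where it says the series, first, only, none or still open, it means among the compounds named here.

Measured so far in a physicochemical assay for lipophilicity, at pH 7.4; on this read-out lower numbers stand for lower lipophilicity and higher numbers for higher lipophilicity:
Compound 1, `Nc1ccc(NC2=NCCC3(CCCCC3)S2)cc1`, gives -0.52.
Compound 2, `CC(=O)c1cccc(NC2=NCCC3(CCCCC3)S2)c1`, gives 1.31.

Of these two numbers, compound 1 stands at the bottom; compound 2 sits higher in this assay, by a gap beyond the usual scatter. Compound 3, `CC(C)c1ccc(NC2=NCCC3(CCCCC3)S2)cc1`, shares the core of compound 1 and differs in one place: isopropyl in place of amino on an aromatic carbon. For the measured compounds named here, no measured pair shows this exact change, so the expectation rests on the structures alone. A rise well beyond the scatter is expected, a number 3.32 log units higher from compound 1 to compound 3 (beyond the scatter). Compound 3 is therefore estimated at 2.8, within a range from 2 to 3.6.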

Compound 3, distribution coefficient: 1.45
Compound 3: middle estimate off by 1.35 log units, on the high side; measured number outside the range, below it.
By their numbers in this assay, from the lowest: compound 1; then compounds 2 and 3 (each within the scatter of the next).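

In this assay, for the compounds shown here, the first step between compounds that differ in one place is large: isopropyl in place of amino on an aromatic carbon, para to a large group, gives a number 1.97 log units higher from compound 1 to compound 3 (beyond the scatter). So what sits at this position can move this read-out well beyond the scatter. Nothing available here accounts for the size of this step.

From the compounds shown here alone, it remains open where other groups at this position would fall, such as a methyl, a longer chain or a carboxylic acid. A single step also cannot show whether the same change would give a similar step on another aromatic carbon of this ring.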